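The compounds below may be only part of what the source reports. "The series", "measured", "known", "first", "only" and "open" are said of these compounds alone.

Compound 1 `OC1CCC(Nc2nc(-c3ccccc3)nc3c2nnn3Cc2ccccc2F)CC1` gives 1850000 nM in an assay on isolated protein for binding affinity to adenosine receptor A1 (Bos taurus); on this read-out lower numbers stand for stronger inhibition and higher numbers for weaker inhibition. Compound 2 `CNc1nc(-c2ccccc2)nc2c1nnn2Cc1ccccc1F` gives 25000000 nM.

Compound 2 stands at the highest of the two numbers in this assay; its nearest neighbour is compound 1, and the step of a 14-fold higher number from compound 1 to compound 2 (1.13 log units; beyond the scatter) separates them. Compound 3 `Fc1ccccc1Cn1nnc2c(NC3CC3)nc(-c3ccccc3)nc21` differs from compound 2 by cyclopropyl in place of methyl on a nitrogen on an aromatic ring. Within the data shown here, only that one measured step bears on this change, and it ran toward higher numbers when a smaller group replaced a larger one. Compound 3 is therefore expected to move part of the way back, with an estimated step of a 3.1-fold lower number from compound 2 to compound 3 (0.49 log units; beyond the scatter). The estimate for compound 3 is 8000000 nM, within 2500000 nM to 25000000 nM.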

Compound 3, inhibition constant: 15000000 nM
For compound 3 the middle estimate is 1.9-fold (0.27 log units) below the measured one; measured number inside the range.
By their numbers in this assay, from the lowest: compound 1; then compounds 3 and 2 (each within the scatter of the next).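

In this assay, cyclopropyl in place of methyl on this nitrogen gives a 1.7-fold lower number from compound 2 to compound 3 (0.22 log units; within the scatter) and that lies within the scatter, so the two groups cannot be told apart here. The 4-hydroxycyclohexyl group keeps its distance, with an 8.1-fold higher number from compound 1 to compound 3 (0.91 log units; beyond the scatter) beyond the scatter, and among these three only compound 1 stands apart. No measured evidence bears on the reason for this. The compounds shown leave open whether a plain cyclohexyl without the hydroxyl, or an open chain such as butyl, would match compound 1.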